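This account rests on a few compounds, and the source may have more. Where it says the series, first, only, none or still open, it means among the compounds named here.

Compound 1, with the structure `COc1ccc(/C=N/Nc2nc(C)c[se]2)cc1`, reaches only a limit in a functional assay on DU-145 cells (Homo sapiens) for cytotoxicity, read by XTT assay, with a stated time of 72 h (a lower number here means a stronger inhibitor, a higher number a weaker inhibitor), namely > 84900 nM. Compound 2, built as `COc1ccc(/C=N/Nc2nc(-c3ccccc3)c[se]2)cc1`, gives in this assay a measured number, 50900 nM. The change from the first to the second is phenyl in place of methyl on an aromatic carbon, and the step it made is an at least 1.6-fold lower number from compound 1 to compound 2 (0.22 log units; that floor lies within the scatter); the starting point here is the limit described by the limit of > 84900 nM in this assay, at which 1 of the 3 values shown sits.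

Compound 3, with the structure `Cc1c[se]c(NNC(=O)c2ccccc2)n1`, also stops at a limit in this assay, > 89200 nM, the one described by the limit of > 89200 nM in this assay, at which 1 of the 3 values shown sits. How the core of compound 3 differs from that of compound 1 is not broken down here.

Compound 4, drawn as `O=C(NNc1nc(-c2ccccc2)c[se]1)c1ccccc1`, carries the same change, (phenyl in place of methyl on an aromatic carbon), on a different core. The step from compound 3 to compound 4 is expected to be an at least 1.6-fold lower number from compound 3 to compound 4 (0.21 log units; that floor lies within the scatter), resting on the measured step of an at least 1.6-fold lower number from compound 1 to compound 2 (0.22 log units; that floor lies within the scatter). For compound 4 the estimate is 55000 nM, between 20000 nM and 150000 nM.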

Compound 4, half-maximal inhibitory concentration: > 73000 nM
Compound 4 gave a limit, no number; the forecaster's own chance of this, stated with the estimate: 45%; at least 1.3-fold (0.12 log units) between middle value and limit.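

Compound 3 and compound 4 both stop at limits in this assay, so no step can be read between them. The compounds shown leave open whether phenyl in place of methyl changes the number on this core at all.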